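The source may hold more compounds than are shown below. What is called first, only, known or untested is meant among the compounds shown, and "the series" means these compounds.

Measured compounds:
Compound 1, `CCSC(=S)N[C@H]1CCOC1=O`: in a functional assay on MGC-803 cells (Homo sapiens) for cytotoxicity, read by MTT assay, with a stated time of 72 h (a higher number here means a weaker inhibitor, a lower number a stronger inhibitor), compound 1 gives > 128000 nM, a limit of the assay rather than a number.
Compound 2, `CCCCCCSC(=S)N[C@H]1CCOC1=O`: in this assay compound 2 gives > 128000 nM, again a limit.
Compound 3, `CCCCCCCCSC(=S)N[C@H]1CCOC1=O`: in this assay compound 3 gives > 128000 nM, also a limit.

Compound 3 therefore stands only at a ceiling, and the two other values shown stand at the same ceiling, (the limit of > 128000 nM in this assay, at which 3 of the 3 values shown sit). The chain-lengthening steps among these compounds, a step that the two limits leave unreadable from compound 1 to compound 2, a step that the two limits leave unreadable from compound 1 to compound 3 and a step that the two limits leave unreadable from compound 2 to compound 3, are all bounded by limits at both ends, so none of them has a readable size or direction.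

Compound 4, `CCCCCCCCCCCCSC(=S)N[C@H]1CCOC1=O`, differs from compound 3 by butyl in place of hydrogen on a saturated chain carbon, eight bonds along the chain from a sulfur. Within the data shown here, the steps that bear on this change are the three chain extensions just named, and since every one of them is unreadable, no size and no direction can be drawn from them. The expected step from compound 3 to compound 4 is a step that the limit leaves unreadable from compound 3 to compound 4, meaning that the value is expected to stay at the ceiling rather than move beyond the scatter. Compound 4 in this assay is estimated at 150000 nM, with a range from 50000 nM to 400000 nM, most probably reported again only as a limit.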

Compound 4, half-maximal inhibitory concentration: 33300 nM
Estimate against measurement, compound 4: 4.5-fold (0.65 log units) above; the measured number lies below the stated range.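

In this assay the series gives its first readable change: butyl in place of hydrogen on a saturated chain carbon, eight bonds along the chain from a sulfur, produces an at least 3.8-fold lower number from compound 3 to compound 4 (0.58 log units; beyond the scatter) and so moves the number off the ceiling. The larger chain extension reads the same way, with an at least 3.8-fold lower number from compound 2 to compound 4 (0.58 log units; beyond the scatter) on the same shared core. Chain extension at this position can therefore lower the number, but only the extension to the chain of compound 4 has done so, and both steps are lower bounds, with the shorter chains giving only a limit: the limit of > 128000 nM in this assay, at which 3 of the 4 values shown sit.

With a single number in the series, the compounds shown leave open whether a longer chain such as tetradecyl would lower the value further or whether the effect would level off or reverse. They also leave open whether the step needs a plain carbon chain, or whether a terminal amine or carboxylic acid on the same chain would keep it.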